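Fluoro to nitro on compound 1

The source may hold more compounds than are shown below. What is called first, only, known or untested is meant among the compounds shown, and "the series" means these compounds.

In a functional assay on MDA-MB-231 cells (Homo sapiens) for antiproliferative activity, read by sulforhodamine B assay, with a stated time of 48 h (on this read-out higher numbers stand for weaker inhibition and lower numbers for stronger inhibition), compound 1 (`COc1ccc2nc(-c3ccc(N/C=C\C(=O)c4ccc(OC)c(F)c4)c(C)c3)sc2c1`) gives 2000 nM while compound 2 (`COc1ccc2nc(-c3ccc(N/C=C\C(=O)c4ccc(OC)c(F)c4)cc3)sc2c1`) gives 1100 nM and the two lie within the usual scatter of each other. Compound 3 (`COc1ccc2nc(-c3ccc(N/C=C\C(=O)c4ccc(OC)c([N+](=O)[O-])c4)c(C)c3)sc2c1`) keeps the core of compound 1 but has nitro in place of fluoro on an aromatic carbon, ortho to a methoxy group (nitro in place of fluoro on an aromatic carbon). For the measured compounds named here, the only measured step (a 1.8-fold lower number from compound 1 to compound 2 (0.26 log units; within the scatter)) is hydrogen in place of methyl, a change elsewhere in the molecule, so it bears on this swap only indirectly. Going by the values given here, no measured compound carries nitro, so no step beyond the scatter is expected in this assay for this swap, and that expectation is loose. The expected change (a 1.1-fold lower number from compound 1 to compound 3 (0.05 log units; within the scatter)) stays inside the scatter. Compound 3 is estimated at 1800 nM with an expected range from 600 nM to 5000 nM as a rough guide.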

Compound 3, half-maximal inhibitory concentration: 17600 nM
Compound 3: the middle estimate sits 9.8-fold (0.99 log units) below what was measured; measured number outside the range, above it.
By their numbers in this assay, from the lowest: compounds 2 and 1 (each within the scatter of the next); then compound 3.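

Nitro in place of fluoro on this aromatic carbon, ortho to a methoxy group, gives in this assay an 8.8-fold higher number from compound 1 to compound 3 (0.94 log units; beyond the scatter), so this position does not tolerate every substituent equally in this assay. The earlier step, hydrogen in place of methyl, changed a different place and stayed within the scatter, so this is the first change shown to move the number beyond it. The swap replaces one heavy atom with three and adds two hydrogen-bond acceptors, but nothing shown explains why the number rose.

The compounds shown leave open how an amine, a nitrile or plain hydrogen on this carbon would compare with fluoro and nitro. They also leave open whether nitro would give a similar step on compound 2, which lacks the methyl group.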